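The source may hold more compounds than are shown below. What is called first, only, known or untested is meant among the compounds shown, and "the series" means these compounds.

Compound 1, `Cc1ccc(OCC(=O)N(Cc2cccs2)CC(C)C)cc1`, gives 900 nM in an assay on HEK293 cells for agonist activity at transient receptor potential cation channel subfamily M member 8 (Homo sapiens), read by fluorescence and calcium flux, with a stated time of 15 min; a lower number here means that less compound is needed, a higher number that more compound is needed for the effect. Going by the values given here, of the two compounds measured so far it stands at the higher end: the other, compound 2, `Cc1ccc(/C=C/C(=O)N(Cc2cccs2)c2ccn[nH]2)cc1`, gives 0.004 nM in this assay, a far lower number, beyond the usual scatter. Compound 2 differs from compound 1 in more than one place, so the gap between their values cannot be tied to any single change. The unmeasured compound 3, `Cc1ccc(OCC(=O)N(Cc2cccs2)c2ncccn2)cc1`, departs from compound 1 in only one place: pyrimidin-2-yl in place of isobutyl on an amide-type nitrogen. Among the compounds with values here, no measured pair differs in just this way, so the size of the step cannot be read directly from data. Still, the value of compound 2 shows that this series can reach numbers well under that of compound 1, and the change toward one six-membered aromatic ring with 2 hetero atoms on the amide-type nitrogen is expected to move the number downward in this assay by more than the scatter, as a 15-fold lower number from compound 1 to compound 3 (1.18 log units; beyond the scatter) expresses. Compound 3 is estimated at 60 nM, with a range from 5 nM to 600 nM.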

Compound 3, half-maximal effective concentration: 3700 nM
Compound 3: the middle estimate sits 62-fold (1.79 log units) below what was measured, outside the stated range (above it).
By their numbers in this assay, from the lowest: compound 2; then compound 1; then compound 3.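

Going by these compounds alone, on the amide-type nitrogen whose other neighbours are a carbonyl carbon and a saturated chain carbon, putting pyrimidin-2-yl in place of isobutyl gives, in this assay, a 4.1-fold higher number from compound 1 to compound 3 (0.61 log units; beyond the scatter), a modest step but one beyond the scatter, and the first direct reading of a single change at this position. A higher number means that more compound is needed for the effect, so on the core of compound 1 this one aromatic ring with its two hetero atoms does not bring the number down; exchanging the saturated chain for it moves the number the other way. Nothing at hand explains why the step points in this direction.

The compounds shown leave open whether this rise belongs to pyrimidin-2-yl in particular or to rings in general at this place, a question that a phenyl or a cyclohexyl group on the same nitrogen would help to settle. Going by these compounds, it also remains open whether the same exchange would give a step of similar size and direction with a different group on the other side of the amide, as this single pair is the only one that differs in just one place.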